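Replacing Tert-Butylphenyl with Fluorodimethylphenyl on Compound 3

A few compounds are considered here, and "the series" means these few. Any claim that something is new, unique, unknown or untested is made for them only; others in the source may bear on it.

The account covers three measured compounds and one that awaits measurement in a functional assay on KYSE-410 cells (Homo sapiens) for antiproliferative activity, read by MTT assay, with a stated time of 72 h; on this read-out lower numbers stand for stronger inhibition and higher numbers for weaker inhibition. Compound 1 `O=C(Nc1ccc(C(F)(F)F)cc1)c1cc(=O)[nH]c2cc(Br)ccc12` reaches only the limit of this assay, giving > 20000 nM. Compound 2 `O=C(Nc1cccc(Cl)c1)c1cc(=O)[nH]c2cc(Br)ccc12` likewise stops at the limit, with > 20000 nM. Compound 3 `CC(C)(C)c1ccc(-c2ccc3c(C(=O)Nc4cccc(F)c4)cc(=O)[nH]c3c2)cc1` also sits at the limit, recorded as > 20000 nM, so it stands nowhere above the other two; indeed (the limit of > 20000 nM in this assay, at which 3 of the 3 values shown sit), and no number separates any of them.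

Compound 4 `Cc1cc(-c2ccc3c(C(=O)Nc4cccc(F)c4)cc(=O)[nH]c3c2)c(C)cc1F` differs from compound 3 in one place: 4-fluoro-2,5-dimethylphenyl in place of 4-(tert-butyl)phenyl on an aromatic carbon. For the measured compounds named here, no step between measured compounds is available to guide the size of this change. Given that compound 3 itself offers only a limit, > 20000 nM, the step in this assay is expected to be small or none beyond the scatter, with compound 4 most likely remaining at or near the limit. Compound 4 is therefore estimated at 25000 nM, within a range from 5000 nM to 100000 nM. The expected step is a step that the limit leaves unreadable from compound 3 to compound 4.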

Compound 4, half-maximal inhibitory concentration: > 20000 nM
Compound 4 was reported as a limit; the forecaster's own chance of this, stated with the estimate: 75%; the middle value is on the limit's open side.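

Compound 4, like compound 3, is recorded only as a limit in this assay, so no step can be read from compound 3 to compound 4: the limit of > 20000 nM in this assay, at which 4 of the 4 values shown sit.

With no number among them, the compounds shown leave open which structural change, if any, would give a measurable value in this assay.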